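Swapping thiophen-2-yl for furan-2-yl in an inactive compound

A few compounds are considered here, and "the series" means these few. Any claim that something is new, unique, unknown or untested is made for them only; others in the source may bear on it.

In a functional assay on PC-3 cells (Homo sapiens) for inhibition, read by sulforhodamine B assay, with a stated time of 48 h, tested at 50 uM (on this read-out lower numbers stand for less inhibition of growth and higher numbers for more inhibition of growth at the one concentration tested), compound 1 (`COc1cc(/C=C/C(=O)/C=C/c2cccs2)ccc1OCc1cn(CCCCCOc2cc(=O)oc3ccccc23)nn1`) is recorded as "not active" (no number reported) and so has no single number to start from. The nearest figure comes from a relative with a different structure, since in this assay compound 2 (`COc1ccc(/C=C/C(=O)/C=C/c2ccc(OCc3cn(CCOc4cc(=O)oc5ccccc45)nn3)c(OC)c2)cc1OC`) gives 19% and no more. The change to compound 3 (`COc1cc(/C=C/C(=O)/C=C/c2ccco2)ccc1OCc1cn(CCCCCOc2cc(=O)oc3ccccc23)nn1`) is furan-2-yl in place of thiophen-2-yl on a double-bonded chain carbon bound to a double-bonded chain carbon on a double-bonded chain carbon bound to a double-bonded chain carbon. Going by the values given here, no measured pair shows this swap, so with compound 1 at "not active" (no number reported) no step beyond the usual scatter is expected in this assay. Compound 3 is estimated at 10% (expected range 0% to 25%).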

Compound 3, percent growth inhibition at one concentration: "not active" (no number reported)
Compound 3: no number reported; the estimate stays without a comparison.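

In this assay compound 1 gives "not active" (no number reported) and compound 3 gives "not active" (no number reported), so no step can be read between them. From the compounds shown here alone, whether swapping thiophen-2-yl for furan-2-yl changes growth inhibition at all stays open. No evidence bears on these results.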